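Replacing the Amide Group with Cyclohexyl

The source may hold more compounds than are shown below. What is called first, only, known or untested is meant among the compounds shown, and "the series" means these compounds.

In an in vitro ADME assay on microsomes from liver (Homo sapiens) for pharmacokinetics (a higher number here means faster removal of the compound, a lower number slower removal), compound 1 (`Cc1ccc(S(=O)(=O)N2C=CNC(=O)[C@H]2CC(=O)N[C@@H]2CCCc3ccccc32)cc1`) gives 514 mL.min-1.g-1. Compound 2 (`Cc1ccc(S(=O)(=O)N2C=CNC(=O)[C@H]2CC(=O)NC2CCNc3ccccc32)cc1`) gives < 50 mL.min-1.g-1, which is a limit of the assay and not a number. Going by the values given here, the only measured step, an at least 10-fold lower number from compound 1 to compound 2 (1.01 log units; beyond the scatter), is large and lies beyond the scatter. It shows that changing the group on the amide-type nitrogen can shift this read-out strongly.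

Compound 3 (`Cc1ccc(S(=O)(=O)N2C=CNC(=O)[C@H]2CC(=O)NC2CCCCC2)cc1`) changes that same place: a group of 6 heavy atoms (6 carbon; one six-membered non-aromatic ring of carbon only) in place of a group of 10 heavy atoms (9 carbon, 1 nitrogen; one six-membered non-aromatic ring with 1 hetero atom, one six-membered aromatic ring of carbon only), on an amide-type nitrogen. Its cyclohexyl ring is of carbon only, and the group in compound 1 also has only carbon rings. One step is thin support, but a clear rise in this assay is expected, probably not all the way to the level of compound 1. The expected change is an at least 3.4-fold higher number from compound 2 to compound 3 (0.53 log units; beyond the scatter). For compound 3, the estimate is 170 mL.min-1.g-1, with an expected range of 60 mL.min-1.g-1 to 480 mL.min-1.g-1.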

Compound 3, intrinsic clearance in microsomes: 147 mL.min-1.g-1
Estimate against measurement, compound 3: 1.2-fold (0.06 log units) above; low and high end bracket the measured number.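

Compound 3 shows that the amide-type nitrogen can carry a carbon-only group without reaching the level of compound 1: in this assay there is a 3.5-fold lower number from compound 1 to compound 3 (0.54 log units; beyond the scatter). So, among these two carbon-only groups, cyclohexyl, which has no aromatic ring, gives the lower number. The nitrogen-containing group of compound 2 also stands apart from cyclohexyl, with an at least 2.9-fold higher number from compound 2 to compound 3 (0.46 log units; beyond the scatter). The value of compound 2 is a limit of the assay and not a number, so the full size of that step stays unknown: the limit of < 50 mL.min-1.g-1 in this assay, at which 1 of the 3 values shown sits.

Still open, going by these compounds, is whether the ring nitrogen alone accounts for the low number of compound 2, or whether it depends on the attached aromatic ring. A piperidin-4-yl group or an open n-butyl chain on the same nitrogen would help to separate these two readings.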